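The source may hold more compounds than are shown below. What is called first, only, known or untested is meant among the compounds shown, and "the series" means these compounds.

In a functional assay on A549 cells (Homo sapiens) for antiproliferative activity, tested at 1 uM (a lower number here means less inhibition, a higher number more inhibition at the concentration tested (going by the name of the read-out)), compound 2 `Cc1nn(C)c(Oc2ccccc2)c1/C=N/OCc1ccc([N+](=O)[O-])cc1` gives 39.4%, which among the three numbers shown is the lowest, though all three lie within the scatter of one another: compound 1 `Cc1nn(C)c(Oc2ccc(Cl)cc2)c1/C=N/OCc1ccc([N+](=O)[O-])cc1` gives 39.6%, and compound 3 `COc1ccc(CO/N=C/c2c(C)nn(C)c2Oc2ccc(Cl)cc2)cc1` gives 43.9%. The step of a number 0.2 percentage points lower from compound 1 to compound 2 (within the scatter) shows that hydrogen in place of chloro on an aromatic carbon left the inhibition where it was. The step of a number 4.3 percentage points higher from compound 1 to compound 3 (within the scatter) shows that methoxy in place of nitro on an aromatic carbon likewise stayed within the scatter. Compound 4 `Cc1ccc(CO/N=C/c2c(C)nn(C)c2Oc2ccccc2)cc1` differs from compound 2 by methyl in place of nitro on an aromatic carbon, a change on an aromatic carbon of a six-membered aromatic ring of carbon only. Going by the values given here, of the measured steps, only the one from compound 1 to compound 3 touches the same nitro group, and it was small; nothing recorded addresses methyl at that site. The account therefore expects no step beyond the scatter, an estimated a number 0.6 percentage points higher from compound 2 to compound 4 (within the scatter). Compound 4 is expected to give an estimated 40%, between 28% and 52%.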

Compound 4, a percentage reported as inhibition, at one concentration (the size of the read-out at that concentration, not a potency): 29.1%
Compound 4: the middle estimate sits 10.9 percentage points above what was measured, within the range that was stated.
By their numbers in this assay, from the lowest: compound 4; then compounds 2, 1 and 3 (each within the scatter of the next).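

In this assay the change from 4-nitrophenyl to 4-methylphenyl gives a number 10.3 percentage points lower from compound 2 to compound 4 (beyond the scatter), so the group at this position can matter, which the step with methoxy in place of nitro, a number 4.3 percentage points higher from compound 1 to compound 3 (within the scatter), did not show. That methoxy step was taken with chloro on the aromatic ring of the shared core's ether, and the methyl step with hydrogen there, so the two steps differ in both the entering group and the background and do not isolate methyl from methoxy. Nothing shown here explains the size of the new step.

As far as these compounds go, whether methyl gives a similar step when chloro is present remains open. So does the outcome with an amine, a carboxylic acid or a longer alkyl chain at this position, and a single concentration says nothing about potency.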